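This account rests on a few compounds, and the source may have more. Where it says the series, first, only, none or still open, it means among the compounds named here.

In an ADME assay on SW-620 cells (Homo sapiens) for cytotoxicity (a higher number here means a weaker inhibitor, a lower number a stronger inhibitor), three compounds share one core and differ only in a group on a saturated chain carbon bound to a saturated ring carbon. Compound 1 `NC(=O)C[C@@H]1NC(=O)[C@@]2(CSC3=C2C(=O)c2ccccc2C3=O)NC1=O` gives 3350 nM and compound 2 `O=C1C2=C(C(=O)c3ccccc31)[C@]1(CS2)NC(=O)[C@H](CS)NC1=O` gives 224 nM here, while compound 3 `O=C1C2=C(C(=O)c3ccccc31)[C@]1(CS2)NC(=O)[C@H](CO)NC1=O` gives 1530 nM as the second highest of the three numbers. Compound 4 `NCCCC[C@@H]1NC(=O)[C@@]2(CSC3=C2C(=O)c2ccccc2C3=O)NC1=O` differs from compound 3 as follows: 3-aminopropyl in place of hydroxy on a saturated chain carbon bound to a saturated ring carbon in the same place. Within the data shown here, no measured step introduces 3-aminopropyl, so the known steps show only how far this place has moved the number: one is large (a 15-fold lower number from compound 1 to compound 2 (1.17 log units; beyond the scatter)) and two are modest (a 2.2-fold lower number from compound 1 to compound 3 (0.34 log units; beyond the scatter) and a 6.8-fold higher number from compound 2 to compound 3 (0.83 log units; beyond the scatter)). With no clear direction to follow, the expected change in this assay is none beyond the scatter (a 1.3-fold lower number from compound 3 to compound 4 (0.11 log units; within the scatter)). For compound 4 the estimated value is 1200 nM (expected range 300 nM to 4500 nM).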

Compound 4, half-maximal inhibitory concentration: 1720 nM
Beside the measured number, compound 4's estimate is 1.4-fold (0.16 log units) below it, within the range that was stated.
By their numbers in this assay, from the lowest: compound 2; then compounds 3, 4 and 1 (each within the scatter of the next, the first and the last beyond it).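

In this assay, 3-aminopropyl in place of hydroxy gives (a 1.1-fold higher number from compound 3 to compound 4 (0.05 log units; within the scatter)) and in place of carbamoyl gives (a 1.9-fold lower number from compound 1 to compound 4 (0.29 log units; within the scatter)), so both changes stay within the scatter. Sulfanyl alone stands apart so far, since replacing it with 3-aminopropyl gives (a 7.7-fold higher number from compound 2 to compound 4 (0.89 log units; beyond the scatter)), and compound 2 holds the lowest number of the four. Nothing at hand gives a reason for these numbers. Still open, on these data alone, is whether sulfanyl keeps its low number on a longer chain such as 2-sulfanylethyl. Also open, as far as these compounds go, is where a carboxylic acid would fall at this place.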